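The compounds below may be only part of what the source reports. "The series", "measured", "known", "first", "only" and "open" are said of these compounds alone.

The series shares one core carrying a methoxyphenoxyethylamino side chain, and its members are tested in a functional assay on SH-SY5Y cells (Homo sapiens) for antiproliferative activity, read by MTT assay, with a stated time of 48 h; a lower number here means a stronger inhibitor of growth, a higher number a weaker inhibitor of growth. Compound 1 `COc1ccccc1OCCNc1cnn(Cc2ccc(OC(F)F)c(OCC3CC3)c2)c(=O)c1Cl` gives only a limit, > 100000 nM. Compound 2 `COc1ccccc1OCCNc1ccc(=O)n(Cc2ccc(OC)c(OC3CCCC3)c2)n1` likewise reaches only a limit, > 100000 nM. Going by the values given here, compound 3 `COc1ccccc1OCCNc1cnn(Cc2ccc(OC)c(OC3CCCC3)c2)c(=O)c1Cl` is the only member with a number, 23300 nM. Compound 2 therefore stands at the bottom of what this set shows, sharing the limit of > 100000 nM in this assay, at which 2 of the 3 values shown sit, with compound 1, so no value for it is known, only that it lies beyond that limit.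

The unmeasured compound 4 `COc1ccc(Cn2nc(NCCOc3ccccc3OC)ccc2=O)cc1Br` differs from compound 2 in a single place: bromo in place of cyclopentyloxy on an aromatic carbon. Among the compounds with values here, no measured pair in the set isolates a change of this kind, so no step can be read off. In this assay the expectation is no step beyond the scatter; compound 4 is expected to stay in the range where compound 2 already sits. The step of a number no higher from compound 2 to compound 4 (the limit leaves the size open) is thus estimated to be essentially flat. Compound 4 is expected at 100000 nM, within 30000 nM to 300000 nM.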

Compound 4, concentration for 50% growth inhibition: > 100000 nM
Compound 4 gave a limit, no number; the forecaster's own chance of this, stated with the estimate: 70%; the middle value sits exactly at the limit.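

Compound 2 and compound 4 each give only a limit in this assay, so no step can be read between them: the limit of > 100000 nM in this assay, at which 3 of the 4 values shown sit.

The compounds shown leave open how far beyond that limit each lies, and so whether bromo in place of cyclopentyloxy changes growth inhibition at all.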